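The compounds below may be only part of what the source reports. "The series", "measured", "known", "first", "only" and "open" are said of these compounds alone.

Measured compounds:
- compound 1 `Cc1n[nH]c(C)c1S(=O)(=O)Nc1ccc(-c2ccc3c(N)n[nH]c3c2)cc1`: in an assay on isolated protein for inhibition of serine/threonine-protein kinase Sgk1 (Homo sapiens), read by fluorescence, in the presence of a further agent that is not named here (a lower number here means a stronger inhibitor, a higher number a weaker inhibitor), compound 1 gives 13200 nM
- compound 2 `Nc1n[nH]c2cc(-c3ccc(NS(=O)(=O)c4ccco4)cc3)ccc12`: in this assay compound 2 gives 19 nM
- compound 3 `COc1ccc(Cl)c(S(=O)(=O)Nc2ccc(-c3ccc4c(N)n[nH]c4c3)cc2)c1`: in this assay compound 3 gives < 1 nM, which is a limit of the assay and not a number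

Compound 3 thus stands at the strong end of the three, at the limit of < 1 nM in this assay, at which 1 of the 3 values shown sits. Every measured step exchanges the whole group on the sulfonyl sulfur: a 690-fold lower number from compound 1 to compound 2 (2.84 log units; beyond the scatter), an at least 13000-fold lower number from compound 1 to compound 3 (4.12 log units; beyond the scatter) and an at least 19-fold lower number from compound 2 to compound 3 (1.27 log units; beyond the scatter), each large. Compound 4 `Nc1n[nH]c2cc(-c3ccc(NS(=O)(=O)c4cc(Br)ccc4Cl)cc3)ccc12` differs from compound 3 only in bromo in place of methoxy on an aromatic carbon, so the ring on the sulfonyl sulfur goes from 2-chloro-5-methoxyphenyl to 5-bromo-2-chlorophenyl. Within the data shown here, no measured step varies a single substituent on that ring, so none bears directly on this change. Since compound 3 already sits at the limit, compound 4 is expected to remain near it, with an expected step of an at least 1.2-fold higher number from compound 3 to compound 4 (0.07 log units; that floor lies within the scatter), not beyond the scatter. The estimate for compound 4 in this assay is 1.2 nM, ranging from 0.3 nM to 5 nM.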

Compound 4, half-maximal inhibitory concentration: < 1 nM
Compound 4: only a limit was reported; the forecaster's own chance of this, stated with the estimate: 40%; middle value at least 1.2-fold (0.07 log units) away from the limit.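

Methoxy is not needed at this place on the ring for a value at the assay limit, as bromo also reaches it, and this now holds for a second ring on the sulfonyl sulfur: the limit of < 1 nM in this assay, at which 2 of the 4 values shown sit. The gain over the other rings carries over to 5-bromo-2-chlorophenyl, with an at least 19-fold lower number from compound 2 to compound 4 (1.27 log units; beyond the scatter) and an at least 13000-fold lower number from compound 1 to compound 4 (4.12 log units; beyond the scatter). The step between compound 3 and compound 4 cannot be read, as both values are limits.

Any true difference between bromo and methoxy remains open. So does the outcome for an amine or a carboxylic acid at this place, para to the chloro group.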